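This account rests on a few compounds, and the source may have more. Where it says the series, first, only, none or still open, it means among the compounds named here.

Measured in a functional assay on HepG2 cells (Homo sapiens) for antiproliferative activity, read by MTT assay, with a stated time of 24 h; a higher number here means a weaker inhibitor, a lower number a stronger inhibitor:
- compound 1 `c1ccc(CSc2nnc(-c3ccc4c(c3)OCCO4)n2-c2ccccc2)cc1`: 5960 nM
- compound 2 `O=[N+]([O-])c1cccc(CSc2nnc(-c3ccc4c(c3)OCCO4)n2-c2ccccc2)c1`: 49300 nM
- compound 3 `Clc1ccccc1CSc1nnc(-c2ccc3c(c2)OCCO3)n1-c1ccccc1`: 970 nM

Compound 1 holds the second highest of the three numbers, with compound 3 lower and compound 2 higher. Compound 4 `Cc1ccccc1CSc1nnc(-c2ccc3c(c2)OCCO3)n1-c1ccccc1` differs from it by methyl in place of hydrogen on an aromatic carbon, a methyl in place of hydrogen on an aromatic carbon, ortho to a large group. Among the compounds with values here, two measured steps bear on this change. Within the data shown here, the chloro step, a 6.1-fold lower number from compound 1 to compound 3 (0.79 log units; beyond the scatter), was modest and gives the 2-chlorophenyl analogue, the nearest precedent. The nitro step, an 8.3-fold higher number from compound 1 to compound 2 (0.92 log units; beyond the scatter), was also modest but ran the other way, and it gives the 3-nitrophenyl analogue. A modest step towards a lower number is therefore expected in this assay, smaller than the chloro step. The expected change is a 2.4-fold lower number from compound 1 to compound 4 (0.38 log units; beyond the scatter). For compound 4 the estimated value is 2500 nM, with an expected range of 800 nM to 8000 nM.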

Compound 4, half-maximal inhibitory concentration: 20500 nM
Compound 4: middle estimate off by 8.2-fold (0.91 log units), on the low side; the measured number lies above the stated range.
By their numbers in this assay, from the lowest: compound 3; then compound 1; then compound 4; then compound 2.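

In this assay, methyl at this place moves the number up (a 3.4-fold higher number from compound 1 to compound 4 (0.54 log units; beyond the scatter)), so the lowering seen with chloro does not carry over to methyl. Exchanging these two groups at this place is a large step (a 21-fold higher number from compound 3 to compound 4 (1.32 log units; beyond the scatter)), while the gap to the 3-nitrophenyl analogue is smaller (a 2.4-fold lower number from compound 2 to compound 4 (0.38 log units; beyond the scatter)). No measurement here accounts for the difference between chloro and methyl.

Going by these compounds, whether fluoro, bromo or methoxy at this place follows chloro or methyl remains open. So does the effect of chloro or methyl elsewhere on this ring.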